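Swapping a methoxyphenyl for a bromophenyl on the shared core

The source may report more compounds than this note shows. Statements on the series, on what has been measured and on what is new or still open speak of the compounds shown alone.

Three compounds share one core and differ only in the group on a nitrogen on an aromatic ring. Compound 1 `C=CC(=O)Nc1cccc(NC(=O)CSc2nc(Nc3ccccc3F)c3ccccc3n2)c1`, compound 2 `C=CC(=O)Nc1cccc(NC(=O)CSc2nc(Nc3cccc(Cl)c3)c3ccccc3n2)c1` and compound 3 `C=CC(=O)Nc1cccc(NC(=O)CSc2nc(Nc3cccc(OC)c3)c3ccccc3n2)c1` were tested in a functional assay on MGC-803 cells (Homo sapiens) for inhibition, read by MTT assay, with a stated time of 72 h (a higher number here means a weaker inhibitor, a lower number a stronger inhibitor), where compound 1 gives 26100 nM, compound 2 gives 7830 nM and compound 3 gives 24200 nM. Compound 3 sits near the weak end: a 1.1-fold lower number from compound 1 to compound 3 (0.03 log units; within the scatter), whereas a 3.1-fold higher number from compound 2 to compound 3 (0.49 log units; beyond the scatter). Compound 4 `C=CC(=O)Nc1cccc(NC(=O)CSc2nc(Nc3ccc(Br)cc3)c3ccccc3n2)c1` carries 4-bromophenyl in place of 3-methoxyphenyl on a nitrogen on an aromatic ring. Among the compounds with values here, since a 3.3-fold lower number from compound 1 to compound 2 (0.52 log units; beyond the scatter) made compound 2 the strongest of the three, and a halogen again replaces the methoxy, a modest improvement in this assay is expected, about a 2.0-fold lower number from compound 3 to compound 4 (0.30 log units; within the scatter), though no measured compound carries a 4-bromophenyl. Compound 4 is estimated at 12000 nM, within 4000 nM to 35000 nM.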

Compound 4, half-maximal inhibitory concentration: 11500 nM
Compound 4: the middle estimate sits 1.0-fold (0.02 log units) above what was measured; low and high end bracket the measured number.
By their numbers in this assay, from the lowest: compounds 2 and 4 (each within the scatter of the next); then compounds 3 and 1 (each within the scatter of the next).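

At this position, a 4-bromophenyl clearly improves on both the 3-methoxyphenyl (a 2.1-fold lower number from compound 3 to compound 4 (0.32 log units; beyond the scatter)) and the 2-fluorophenyl (a 2.3-fold lower number from compound 1 to compound 4 (0.36 log units; beyond the scatter)). It cannot be told apart from the 3-chlorophenyl (a 1.5-fold higher number from compound 2 to compound 4 (0.17 log units; within the scatter)), so a second halogen-bearing ring joins the better group, although the fluorine-bearing compound 1 goes against any simple halogen rule. No available evidence explains these differences.

As far as these compounds go, compound 2 and compound 4 differ in both the halogen and its place on the ring, so the contribution of each remains open. How an amine or a carboxylic acid on this ring would behave is also unknown.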